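A few compounds are considered here, and "the series" means these few. Any claim that something is new, unique, unknown or untested is made for them only; others in the source may bear on it.

Compound 1 `Clc1ccc2[nH]c(-c3cn(-c4ccccc4)nc3-c3ccccc3)nc2c1`: > 50000 nM
Compound 2 `Fc1ccc(-c2nn(-c3ccccc3)cc2-c2nc3ccccc3[nH]2)cc1`: > 50000 nM
Compound 3 `Fc1ccc(-c2nn(-c3ccccc3)cc2-c2nc3cc(F)ccc3[nH]2)cc1`: > 50000 nM

Each of these entries is a limit of the assay and not a number. In an ADME assay on HaCaT cells (Homo sapiens) for cytotoxicity, read by MTT assay, with a stated time of 48 h (a lower number here means a stronger inhibitor, a higher number a weaker inhibitor), compound 3 gives > 50000 nM, which is such a limit. Compound 3 therefore stands at the limit of > 50000 nM in this assay, at which 3 of the 3 values shown sit.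

Compound 4 `Fc1ccc(-c2nn(-c3ccccc3)cc2-c2nc3cc(Cl)ccc3[nH]2)cc1` carries chloro in place of fluoro on an aromatic carbon, (chloro in place of fluoro on an aromatic carbon). The measured step that bears on this is a step that the two limits leave unreadable from compound 2 to compound 3, with fluoro in place of hydrogen on an aromatic carbon. It offers no size or direction to carry over, so no shift beyond the scatter is expected in this assay. The expected change is a step that the limit leaves unreadable from compound 3 to compound 4. Compound 4 is estimated at 60000 nM, with an expected range of 30000 nM to 120000 nM.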

Compound 4, half-maximal inhibitory concentration: > 50000 nM
Compound 4: no number, only a limit; the forecaster's own chance of this, stated with the estimate: 85%; the middle value is on the limit's open side.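

In this assay, going by these compounds alone, compound 4, like compound 1, compound 2 and compound 3, gives only a limit and not a number, so no step among them can be read: the limit of > 50000 nM in this assay, at which 4 of the 4 values shown sit. Going by these compounds, whether these compounds differ from one another at all in this assay remains open.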